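Acetyl Capping of a Hydroxyacetamide Side Chain

A few compounds are considered here, and "the series" means these few. Any claim that something is new, unique, unknown or untested is made for them only; others in the source may bear on it.

Compound 1, `C#CCNC1CCc2c(OCCc3cc(NC(C)=O)ccc3Cl)cccc21`: 590 nM
Compound 2, `C#CCNC1CCc2c(OCCc3cc(NC(=O)c4cccc(F)c4)ccc3Cl)cccc21`: > 20000 nM
Compound 3, `C#CCNC1CCc2c(OCCc3cc(NC(=O)CO)ccc3Cl)cccc21`: 270 nM

Three compounds share one core and differ only in the amide substituent on the chlorophenyl ring. In an assay on cells for inhibition of Amine oxidase [flavin-containing] B (Homo sapiens), read by fluorescence and Amplex Red, with stated times of 30 min and 15 min (on this read-out lower numbers stand for stronger inhibition and higher numbers for weaker inhibition), compound 3 gives the lowest of the two numbers shown, with compound 1 the nearest, as a 2.2-fold lower number from compound 1 to compound 3 (0.34 log units; beyond the scatter) records. For compound 2 the assay reports only a limit, (the limit of > 20000 nM in this assay, at which 1 of the 3 values shown sits), and an at least 33-fold higher number from compound 1 to compound 2 (1.53 log units; beyond the scatter) as well as an at least 74-fold lower number from compound 2 to compound 3 (1.86 log units; beyond the scatter) show how far the 3-fluorophenyl amide falls behind.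

Compound 4, `C#CCNC1CCc2c(OCCc3cc(NC(=O)COC(C)=O)ccc3Cl)cccc21`, is the unmeasured analogue. It differs from compound 3 by acetyl in place of hydrogen on an oxygen on a saturated carbon. For the measured compounds named here, two steps bear on this: the modest gain from hydrogen to hydroxy, and the large loss when a small acyl group is replaced by a 3-fluorophenyl amide. The acetyl cap removes the hydroxy that helped compound 3 and adds bulk, though far less than in compound 2. Compound 4 is therefore expected to be somewhat weaker than compound 3, with an estimated step of a 3.0-fold higher number from compound 3 to compound 4 (0.47 log units; beyond the scatter). Compound 4 is estimated at 800 nM, in the range 250 nM to 3000 nM.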

Compound 4, half-maximal inhibitory concentration: 480 nM
Compound 4: the middle estimate sits 1.7-fold (0.22 log units) above what was measured; the range from low to high includes it.
By their numbers in this assay, from the lowest: compounds 3, 4 and 1 (each within the scatter of the next, the first and the last beyond it). At a limit, above all of these: compound 2.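

Putting acetyl on the oxygen of the hydroxy group does not separate the two compounds in this assay, as a 1.8-fold higher number from compound 3 to compound 4 (0.25 log units; within the scatter) records, so the hydroxy hydrogen is not needed at this place for inhibition at this level. The acetoxy group likewise stands level with the plain hydrogen of the acetamide, a 1.2-fold lower number from compound 1 to compound 4 (0.09 log units; within the scatter), so the 3 heavy atoms of acetyl are tolerated here, whereas the 3-fluorophenyl amide is not, an at least 41-fold lower number from compound 2 to compound 4 (1.61 log units; beyond the scatter). That last step rests on a limit and not a number for compound 2: the limit of > 20000 nM in this assay, at which 1 of the 4 values shown sits.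

The compounds shown leave open whether a methyl ether on this oxygen, an amine or a carboxylic acid in place of the hydroxy, or a longer chain would stay level too. They also leave open how large a group on the carbonyl carbon can be before the loss seen with 3-fluorophenyl sets in.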